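The source may report more compounds than this note shows. Statements on the series, on what has been measured and on what is new or still open speak of the compounds shown alone.

In a functional assay on HepG2 cells (Homo sapiens) for inhibition, read by fluorescence and resazurin assay, with a stated time of 72 h (a lower number here means a stronger inhibitor, a higher number a weaker inhibitor), compound 1 `O=S(=O)(c1ccc(Nc2nccc(Nc3ccc4nc[nH]c4c3)n2)cc1)N1CCOCC1` reaches only a limit, > 25000 nM. Compound 2 `O=C(Nc1ccccc1)Nc1cccc(Nc2nccc(Nc3ccc4cn[nH]c4c3)n2)c1` gives 8200 nM. Compound 3 `O=C(Nc1ccccc1)Nc1cccc(Nc2ncc(Cl)c(Nc3ccc4cn[nH]c4c3)n2)c1` gives 3500 nM, the lower of the two actual numbers. Within the data shown here, the one measured step at this position, a 2.3-fold lower number from compound 2 to compound 3 (0.37 log units; beyond the scatter), is modest and puts chloro in place of hydrogen on an aromatic carbon. Compound 4 `Nc1cnc(Nc2cccc(NC(=O)Nc3ccccc3)c2)nc1Nc1ccc2cn[nH]c2c1` instead has amino in place of chloro on an aromatic carbon. With only the modest 2.3-fold lower number from compound 2 to compound 3 (0.37 log units; beyond the scatter) to go on, a step of similar size towards a higher number is expected in this assay. The expected change is a 1.7-fold higher number from compound 3 to compound 4 (0.23 log units; within the scatter). For compound 4 the estimate is 6000 nM, with an expected range of 2000 nM to 18000 nM.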

Compound 4, half-maximal inhibitory concentration: > 25000 nM
Compound 4: only a limit was reported; the forecaster's own chance of this, stated with the estimate: 10%; middle value at least 4.1-fold (0.61 log units) away from the limit.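

The earlier compounds shown here showed only a modest step at this position, with chloro in place of hydrogen. Amino in place of chloro gives an at least 7.1-fold higher number from compound 3 to compound 4 (0.85 log units; beyond the scatter), and against hydrogen at the same carbon amino gives an at least 3.0-fold higher number from compound 2 to compound 4 (0.48 log units; beyond the scatter), so this change does more than undo the chloro step. Compound 4 gives only a limit of the assay, not a number: the limit of > 25000 nM in this assay, at which 2 of the 4 values shown sit.

On these data alone, it remains open whether fluoro, methyl or methylamino at this position would track chloro or amino in this assay. As far as these compounds go, the true size of both steps also remains open.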